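The source may hold more compounds than are shown below. What is called first, only, known or untested is meant among the compounds shown, and "the series" means these compounds.

Measured so far in a physicochemical assay for solubility, in phosphate buffer, with a stated time of 18 h, at pH 7.4; on this read-out lower numbers stand for lower solubility and higher numbers for higher solubility:
Compound 1 `CCN(CC)C(=O)COc1cc2c(-n3nc(-c4ccccn4)nc3N)ncnc2cc1OC`: 42000 nM
Compound 2 `COc1cc2ncnc(-n3nc(-c4ccccn4)nc3N)c2cc1OCCNC(=O)OC(C)(C)C`: 2000 nM
Compound 3 `CCOC(=O)NCCCOc1cc2c(-n3nc(-c4ccccn4)nc3N)ncnc2cc1OC`: 16000 nM

Compound 3 stands second of the three numbers in this assay, with compound 1 above it and compound 2 below it. Compound 4 `CCCCCCOC(=O)NCCCOc1cc2c(-n3nc(-c4ccccn4)nc3N)ncnc2cc1OC` differs from compound 3 by butyl in place of hydrogen on a saturated chain carbon, two bonds along the chain from an oxygen next to a carbonyl group. The same difference reads as ethoxy to hexyloxy.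

For the measured compounds named here, no measured step makes this change alone. The nearest evidence is an 8.0-fold higher number from compound 2 to compound 3 (0.90 log units; beyond the scatter), where the group on the same oxygen differs, but the chain length differs too. The other two steps show how far changes at this side chain have moved the number: a 2.6-fold lower number from compound 1 to compound 3 (0.42 log units; beyond the scatter), and a 21-fold lower number from compound 1 to compound 2 (1.32 log units; beyond the scatter). Going by the values given here, a fall of modest size is therefore expected, with a large one not excluded, and this rests on only three compounds. The estimated step is a 6.4-fold lower number from compound 3 to compound 4 (0.81 log units; beyond the scatter). For compound 4 the expected value is 2500 nM, within an estimated range of 500 nM to 9000 nM.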

Compound 4, solubility: 1000 nM
Compound 4: middle estimate off by 2.5-fold (0.40 log units), on the high side; the measured number falls inside the stated range.
By their numbers in this assay, from the lowest: compounds 4 and 2 (each within the scatter of the next); then compound 3; then compound 1.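

In this assay the change of hydrogen to butyl on a saturated chain carbon, two bonds along the chain from an oxygen next to a carbonyl group, can now be read on its own, as a 16-fold lower number from compound 3 to compound 4 (1.20 log units; beyond the scatter) on an otherwise unchanged side chain. Compound 4 cannot be ordered against the tert-butoxycarbonyl side chain of compound 2, since a 2.0-fold lower number from compound 2 to compound 4 (0.30 log units; within the scatter) is within the scatter. Against the diethylcarbamoyl side chain, the distance grows to a 42-fold lower number from compound 1 to compound 4 (1.62 log units; beyond the scatter) and no measurement at hand speaks to the reason for any of these steps.

Going by these compounds, whether the number keeps falling with a chain longer than hexyloxy, or only with butyl at this carbon, stays open. Also open, on these data alone, is what an amine or a carboxylic acid at the end of this chain would do to the number.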